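Shifting the Methyl Group: From Compound 1 to Compound 4

The source may hold more compounds than are shown below. What is called first, only, known or untested is meant among the compounds shown, and "the series" means these compounds.

Three compounds have been measured in a functional assay on A549 cells (Homo sapiens) for inhibition, read by CCK-8 assay, with a stated time of 48 h; a higher number here means a weaker inhibitor, a lower number a stronger inhibitor:
compound 1, `COc1cc(-c2ccnc3cc(-c4ccc(C)cc4)nn23)cc(OC)c1OC`, gives 3 nM
compound 2, `COc1cc(-c2ccnc3cc(-c4ccc(C(C)=O)cc4)nn23)cc(OC)c1OC`, gives 4100 nM
compound 3, `COc1ccc(-c2cc3nccc(-c4cc(OC)c(OC)c(OC)c4)n3n2)cc1`, gives 376 nM

Compound 1 stands lowest of the three: a 130-fold higher number from compound 1 to compound 3 (2.10 log units; beyond the scatter), and a 1400-fold higher number from compound 1 to compound 2 (3.14 log units; beyond the scatter). The remaining step, an 11-fold lower number from compound 2 to compound 3 (1.04 log units; beyond the scatter), completes the set. Compound 4, `COc1cc(-c2ccnc3cc(-c4cccc(C)c4)nn23)cc(OC)c1OC`, differs from compound 1 only in 3-methylphenyl in place of 4-methylphenyl on an aromatic carbon. Among the compounds with values here, none of the measured steps moves a group from one position to another; they all exchange the methyl for a different group, and both such exchanges were large, showing that this arm of the shared core responds strongly to what is attached there. A rearrangement of the same atoms is expected to cost less than those exchanges. Compound 4 is therefore expected to show a modest weakening, a 5.0-fold higher number from compound 1 to compound 4 (0.70 log units; beyond the scatter), estimated at 15 nM with a range of 3 nM to 100 nM.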

Compound 4, half-maximal inhibitory concentration: 5730 nM
Compound 4: middle estimate off by 380-fold (2.58 log units), on the low side, and the stated range ends below it.
By their numbers in this assay, from the lowest: compound 1; then compound 3; then compounds 2 and 4 (each within the scatter of the next).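

In this assay, shifting the methyl alone, with the same atoms, gives a 1900-fold higher number from compound 1 to compound 4 (3.28 log units; beyond the scatter) and so shows that this arm of the shared core depends on where the methyl sits, not only on which group is attached. The shift costs as much as the exchange for acetyl: a 15-fold higher number from compound 3 to compound 4 (1.18 log units; beyond the scatter) places compound 4 behind the 4-methoxyphenyl compound, while a 1.4-fold higher number from compound 2 to compound 4 (0.15 log units; within the scatter) leaves it level with the 4-acetylphenyl compound. No evidence here explains this loss. Still open, as far as these compounds go, is how a longer chain such as ethyl, or an amine, would fare in place of the methyl of the 4-methylphenyl, and whether either would be tolerated where the methyl of the 3-methylphenyl sits.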